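The source may report more compounds than this note shows. Statements on the series, on what has been measured and on what is new or still open speak of the compounds shown alone.

Measured so far in a functional assay on NCI-H460 cells (Homo sapiens) for antiproliferative activity, read by XTT assay, with a stated time of 72 h; a lower number here means a stronger inhibitor, a higher number a weaker inhibitor:
compound 1 `COc1ccc(-c2cc3ccccc3nc2C=O)cc1`: > 10000 nM
compound 2 `COc1ccc(-c2cc3ccccc3nc2/C=C/C(=O)c2ccccc2)cc1`: 6670 nM
compound 3 `COc1ccc(-c2cc3ccccc3nc2/C=C/C(=O)c2ccc(O)cc2)cc1`: 6930 nM

The entry for compound 1 is a limit of the assay, not a number (the limit of > 10000 nM in this assay, at which 1 of the 3 values shown sits). That leaves two numbers in this assay. Compound 3, at 6930 nM, stands level with compound 2, at 6670 nM, within the scatter.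

Next is compound 4 `COc1ccc(-c2cc3ccccc3nc2/C=C/C(=O)c2ccc(OC)cc2OC)cc1`, which differs from compound 3 by 2,4-dimethoxyphenyl in place of 4-hydroxyphenyl on a carbonyl carbon. For the measured compounds named here, the only measured step on this aromatic ring is hydroxy in place of hydrogen, a 1.0-fold higher number from compound 2 to compound 3 (0.02 log units; within the scatter). That step stays within the scatter, but it is a smaller exchange than this one and so is only a loose guide. A modest move toward a lower number in this assay is expected, and the range still reaches back to no change. The expected step is a 2.3-fold lower number from compound 3 to compound 4 (0.36 log units; beyond the scatter).

The estimate for compound 4 is 3000 nM, with an expected range of 500 nM to 10000 nM.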

Compound 4, half-maximal inhibitory concentration: 7040 nM
For compound 4 the middle estimate is 2.3-fold (0.37 log units) below the measured one, and the stated range covers the measured number.
By their numbers in this assay, from the lowest: compounds 2, 3 and 4 (each within the scatter of the next). At a limit, above all of these: compound 1.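

For the compounds shown here, the position on the carbonyl carbon now has a larger exchange behind it than the single hydroxy step: in this assay there is a 1.0-fold higher number from compound 3 to compound 4 (0.01 log units; within the scatter), and also a 1.1-fold higher number from compound 2 to compound 4 (0.02 log units; within the scatter). Phenyl, 4-hydroxyphenyl and 2,4-dimethoxyphenyl on this carbonyl carbon thus read alike, so neither the added heavy atoms nor the loss of the hydrogen-bond donor of 4-hydroxyphenyl shows up in the number. Nothing measured here bears on why these three read alike.

Still open, on these data alone, is whether any group on this aromatic ring can move the number beyond the scatter, for instance an amine or a carboxylic acid. Also open, as far as these compounds go, is how far changes elsewhere on the shared core, rather than on this ring, would shift this assay.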